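A few compounds are considered here, and "the series" means these few. Any claim that something is new, unique, unknown or untested is made for them only; others in the source may bear on it.

Values so far in a physicochemical assay for lipophilicity, read by HPLC, measured as chromatographic lipophilicity, at pH 7.4; on this read-out higher numbers stand for higher lipophilicity and lower numbers for lower lipophilicity (two compounds):

Compound 1 `CC(C)(C)C(=O)n1nccc1-c1ccccc1` gives 8.3 in this series
Compound 2 `O=C(C1CCC1)N1N=CCC1c1ccccc1` gives 4.7 in this series

Compound 2 stands lowest of the two at 4.7 in this assay and compound 1 sits higher at 8.3 by more than the usual scatter. Among the measured compounds shown here, no measured pair differs in one place only, and the next change has no direct precedent here.

Compound 3 `O=C(c1ccncc1)N1N=CCC1c1ccccc1` differs from compound 2 by a single change, pyridin-4-yl in place of cyclobutyl on a carbonyl carbon and its value is still to be measured. The anchor for the expectation is compound 2 at 4.7 and its core is shared with compound 3. A modest fall in this assay is expected, with the estimated step of a number 0.40 log units lower from compound 2 to compound 3 (beyond the scatter) only slightly beyond the scatter and a result with no change beyond the scatter still possible. For compound 3 the expected value is 4.3 with an estimated range from 3.4 to 5.2 as the likely span.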

Compound 3, distribution coefficient: 2.7
Estimate against measurement, compound 3: 1.60 log units above; the whole stated range lies above it.
By their numbers in this assay, from the lowest: compound 3; then compound 2; then compound 1.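

In this assay, among the compounds shown here, pyridin-4-yl in place of cyclobutyl on a carbonyl carbon gives a number 2.00 log units lower from compound 2 to compound 3 (beyond the scatter), the first change that can be read at a single place. With the shared core held constant, this position on a carbonyl carbon bonded to an amide-type nitrogen in a ring clearly has a large influence on this read-out, something the two earlier values could not show because compound 1 and compound 2 differ in more than one place. Nothing available here explains the size of this step.

A single step cannot separate the contribution of the ring nitrogen in pyridin-4-yl from that of replacing a four-membered non-aromatic ring with a six-membered aromatic ring, and a phenyl group at the same place would be the direct comparison for telling those apart. On these data alone, it also remains open whether a similar step would appear on the core of compound 1, and how an amine or a carboxylic acid carried on this carbonyl carbon would read in this assay.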